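The compounds below may be only part of what the source reports. "The series", "measured", "known", "first", "only" and "open" are said of these compounds alone.

In a functional assay (aorta) with Oryctolagus cuniculus as the target (on this read-out higher numbers stand for weaker binding and lower numbers for tighter binding), compound 1 `COc1cc(C(C)=O)ccc1OCCCN1CCC(C(c2ccc(F)cc2)c2ccc(F)cc2)CC1` gives 1.59 nM, compound 2 `N#Cc1ccc(OCCCN2CCC(C(c3ccc(F)cc3)c3ccc(F)cc3)CC2)cc1` gives 5.01 nM and compound 3 `COc1ccc(OCCCN2CCC(C(c3ccc(F)cc3)c3ccc(F)cc3)CC2)cc1` gives 2.51 nM. Compound 3 lies within the usual scatter of both others, although those two are separated by a 3.2-fold higher number from compound 1 to compound 2 (0.50 log units; beyond the scatter). Compound 4 `CN(CCCN1CCC(C(c2ccc(F)cc2)c2ccc(F)cc2)CC1)c1ccccc1` has methyl(phenyl)amino in place of 4-methoxyphenoxy on a saturated chain carbon, three bonds along the chain from an amine nitrogen in a ring. The closest guides are changes at this same end: a 1.6-fold higher number from compound 1 to compound 3 (0.20 log units; within the scatter) and a 2.0-fold lower number from compound 2 to compound 3 (0.30 log units; within the scatter). Within the data shown here, no measured step replaces the oxygen itself, so the forecast is uncertain. In this assay, the expected change is small and towards a higher number, an estimated 1.6-fold higher number from compound 3 to compound 4 (0.20 log units; within the scatter). Compound 4 is expected at 4 nM, within an estimated range of 1.3 nM to 13 nM.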

Compound 4, dissociation constant: 2 nM
The estimate for compound 4 lay 2.0-fold (0.30 log units) above the measured number, within the range that was stated.
By their numbers in this assay, from the lowest: compounds 1, 4, 3 and 2 (each within the scatter of the next, the first and the last beyond it).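

In this assay, methyl(phenyl)amino can take the place of 4-methoxyphenoxy on this saturated chain carbon without leaving the usual scatter (a 1.3-fold lower number from compound 3 to compound 4 (0.10 log units; within the scatter)), so this end need not be a phenoxy group. Among these compounds, it also stays within the scatter of 4-acetyl-2-methoxyphenoxy (a 1.3-fold higher number from compound 1 to compound 4 (0.10 log units; within the scatter)), and only the step from 4-cyanophenoxy goes beyond it (a 2.5-fold lower number from compound 2 to compound 4 (0.40 log units; beyond the scatter)). No supporting measurement explains these numbers.

Still open, going by these compounds, is how phenylamino, without the methyl, would read here. A 4-methoxyphenyl group on the same nitrogen would show whether the methoxy matters once the oxygen on the chain is gone.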